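A few compounds are considered here, and "the series" means these few. Any claim that something is new, unique, unknown or untested is made for them only; others in the source may bear on it.

Measured compounds:
Compound 1, `COc1cc(C(O)c2ccc3c(ccn3C)c2)cc(OC)c1OC`, reaches only the limit > 10000 nM.
Compound 2, `CCn1ccc2cc(C(O)c3cc(OC)c(OC)c(OC)c3)ccc21`, reaches only the limit > 10000 nM.
Compound 3, `COc1cc(/C(=N/N)c2ccc3c(ccn3C)c2)cc(OC)c1OC`, reaches only the limit > 10000 nM.

All three were tested in a functional assay on HL-60 cells (Homo sapiens) for cytotoxicity, read by XTT assay, with a stated time of 72 h; on this read-out lower numbers stand for stronger inhibition and higher numbers for weaker inhibition. Each measurement stops at a limit rather than a number, as recorded by the limit of > 10000 nM in this assay, at which 3 of the 3 values shown sit. The step that the two limits leave unreadable from compound 1 to compound 2, the change (methyl in place of hydrogen on a saturated chain carbon bound to an aromatic nitrogen), therefore cannot be read. The cores of compound 1 and compound 3 differ in a way that is not broken down here. Compound 4, `CCn1ccc2cc(/C(=N\N)c3cc(OC)c(OC)c(OC)c3)ccc21`, differs from compound 3 by methyl in place of hydrogen on a saturated chain carbon bound to an aromatic nitrogen, the same change as between compound 1 and compound 2, at the same place. Since the matching step is unreadable and all three measured values rest on (the limit of > 10000 nM in this assay, at which 3 of the 3 values shown sit), the expected step is a step that the limit leaves unreadable from compound 3 to compound 4. Compound 4 is thus estimated at about 15000 nM, between 5000 nM and 50000 nM, most likely again only a limit.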

Compound 4, half-maximal inhibitory concentration: > 1000 nM
Compound 4 gave a limit, no number; the forecaster's own chance of this, stated with the estimate: 85%; the middle value lies beyond the limit too.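

Among the compounds shown here, compound 3 and compound 4 both stop at limits rather than numbers, and no step between them can be read. The compounds shown leave open how large the effect of methyl in place of hydrogen at this place is, if there is any.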